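The source may hold more compounds than are shown below. What is called first, only, known or untested is meant among the compounds shown, and "the series" means these compounds.

Compound 1 has the structure `O=C(Nc1ccc(Br)cc1)Nc1ccc(Nc2ncnc3[nH]ncc23)cc1`; in an assay on isolated protein for inhibition of vascular endothelial growth factor receptor 2 (Danio rerio), read by fluorescence and microscopy, with a stated time of 33 h (on this read-out higher numbers stand for weaker inhibition and lower numbers for stronger inhibition), compound 1 gives > 100000 nM, which is a limit of the assay and not a number.
Compound 2 has the structure `Cc1cccc(NC(=O)Nc2ccc(Nc3ncnc4[nH]ncc34)cc2)c1C`; in this assay compound 2 gives > 100000 nM, again a limit rather than a number.
Compound 3 has the structure `O=C(Nc1ccc(Nc2ncnc3[nH]ncc23)cc1)Nc1ccc(C(F)(F)F)cc1`; in this assay compound 3 gives > 100000 nM, once more a limit and not a number.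

Compound 3 therefore stands exactly where the other two stand, at the edge of what this assay can report, and no order among the three compounds can be read. The three steps that join them, a step that the two limits leave unreadable from compound 1 to compound 2, a step that the two limits leave unreadable from compound 1 to compound 3 and a step that the two limits leave unreadable from compound 2 to compound 3, are all of unreadable size because of the limit of > 100000 nM in this assay, at which 3 of the 3 values shown sit.

Compound 4, with the structure `CC(NC(=O)Nc1ccc(Nc2ncnc3[nH]ncc23)cc1)c1ccccc1`, differs from compound 3 in one place: 1-phenylethyl in place of 4-(trifluoromethyl)phenyl on an amide-type nitrogen. Within the data shown here, every measured step changes the group on that same amide-type nitrogen, and none of them moved a compound off the limit, so no step gives a readable size to lean on. The step of a number no higher from compound 3 to compound 4 (the limit leaves the size open) is thus expected to be small or absent, with the outcome most likely a limit again. Compound 4 is accordingly estimated at 100000 nM, with a range from 20000 nM to 300000 nM in this assay.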

Compound 4, half-maximal inhibitory concentration: > 100000 nM
Compound 4: a limit, no number; the forecaster's own chance of this, stated with the estimate: 80%; the middle value sits exactly at the limit.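

In this assay compound 4 gives > 100000 nM as its reading, a limit and not a number. Its steps from compound 1, compound 2 and compound 3 therefore cannot be read: the limit of > 100000 nM in this assay, at which 4 of the 4 values shown sit.

The compounds shown leave open how far any change of the group on the amide-type nitrogen moves the read-out, as none of them yields a number.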